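Extending propyl to butyl on the shared core

This account rests on a few compounds, and the source may have more. Where it says the series, first, only, none or still open, it means among the compounds named here.

Compound 2 `CCCc1cc2ccccc2nc1-c1cn(-c2ccc(F)cc2)nn1` carries a propyl group on the shared core. In a functional assay on HeLa cells (Homo sapiens) for cytotoxicity, read by MTT assay, with a stated time of 24 h (on this read-out lower numbers stand for stronger inhibition and higher numbers for weaker inhibition), compound 2 gives > 100 ug/mL, which is a limit of the assay and not a number. Compound 1 `Cc1cc2ccccc2nc1-c1cn(-c2ccc(F)cc2)nn1` bears methyl in the same place. In this assay compound 1 gives > 100 ug/mL, again a limit. Compound 3 `CCCCc1cc2ccccc2nc1-c1cn(-c2ccc(F)cc2)nn1` differs from compound 2 by methyl in place of hydrogen on a saturated chain carbon, three bonds along the chain from an aromatic carbon; cut one bond further out, the change reads propyl to butyl. Among the measured compounds shown here, the only measured step bearing on this change is a step that the two limits leave unreadable from compound 1 to compound 2, whose size cannot be read because both values sit at the limit of > 100 ug/mL in this assay, at which 2 of the 2 values shown sit. No step beyond the scatter is therefore expected in this assay. Compound 3 is expected to give 150 ug/mL, with a range from 60 ug/mL to 400 ug/mL, and most likely again only a limit. The step that the limit leaves unreadable from compound 2 to compound 3 is thus the estimate.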

Compound 3, half-maximal inhibitory concentration: > 100 ug/mL
Compound 3: a limit, no number (the forecaster's own chance of this, stated with the estimate: 85%); the middle value is on the limit's open side.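

No step can be read among compound 1, compound 2 and compound 3 in this assay, since each of the three values is a limit and not a number: the limit of > 100 ug/mL in this assay, at which 3 of the 3 values shown sit.

The compounds shown leave open how strongly any of the three acts in this assay, and whether the length of the chain on the shared core changes that at all.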